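A few compounds are considered here, and "the series" means these few. Any claim that something is new, unique, unknown or untested is made for them only; others in the source may bear on it.

Measured so far:
- compound 1, `CCC(CC)CNc1c(C(N)=O)cnc2ccc(C#N)cc12`: 820 nM
- compound 2, `NC(=O)c1cnc2ccc(-c3cccnc3)cc2c1NC1CCCCC1`: 132 nM

In an assay on HT-29 cells for inhibition of Serine-protein kinase ATM (Homo sapiens), read by fluorescence, with a stated time of 1 h (on this read-out lower numbers stand for stronger inhibition and higher numbers for weaker inhibition), compound 1 gives 820 nM and stands highest of the two numbers; compound 2 in this assay gives 132 nM, a lower number beyond the scatter, but compound 2 differs from compound 1 in more than one place, so no single step can be read from that pair.

Compound 3, `CCC(CC)CNc1c(C(N)=O)cnc2ccc(-c3ccncc3)cc12`, is the one-place variant of compound 1: pyridin-4-yl in place of cyano on an aromatic carbon, on the aromatic carbon meta to a fused ring and para to a fused ring of the shared core. Among the measured compounds shown here, no measured step of this kind exists in the set. For the measured compounds named here, the only hint is that compound 2, which carries a pyridinyl at the same place of the core, gives 132 nM in this assay. Compound 3 is therefore expected to fall below compound 1, with a step of a 3.3-fold lower number from compound 1 to compound 3 (0.52 log units; beyond the scatter) estimated. The estimate for compound 3 is 250 nM, within 80 nM to 800 nM.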

Compound 3, half-maximal inhibitory concentration: 418 nM
The estimate for compound 3 lay 1.7-fold (0.22 log units) below the measured number, within the range that was stated.
By their numbers in this assay, from the lowest: compound 2; then compounds 3 and 1 (each within the scatter of the next).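

In this assay, swapping the cyano group for pyridin-4-yl, on the aromatic carbon meta to a fused ring and para to a fused ring, gives a 2.0-fold lower number from compound 1 to compound 3 (0.29 log units; within the scatter), so this exchange of a nitrile for a six-membered aromatic ring does not separate the two compounds on this read-out. Compound 2 differs from compound 3 in more than one place, so that pair cannot be read as a step, and the contribution of the ring at this position to the value of compound 2 stays unassigned. No measurement here offers an explanation for this result.

Still open, from the compounds shown here alone, is whether a primary amine or a carboxylic acid at this carbon would give a number beyond the scatter from compound 1. Also open, going by these compounds, is how the amino substituent of the shared core contributes when the group at this carbon is held constant.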